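Methyl to nitro: one swap, two ring positions

The source may hold more compounds than are shown below. What is called first, only, known or untested is meant among the compounds shown, and "the series" means these compounds.

Of the compounds shown here, three have been measured in a toxicity assay on the whole organism with Rattus norvegicus as the target, at a dose of 200 mg/kg by the oral route; on this read-out higher numbers stand for a stronger effect at the one dose given and lower numbers for a weaker effect. Compound 1 `Cc1ccccc1OCC1=NCCO1` gives 60%. Compound 3 `O=[N+]([O-])c1ccccc1OCC1=NCCO1` differs from compound 1 by nitro in place of methyl on an aromatic carbon. Compound 3 gives 55%. The step of a number 5 percentage points lower from compound 1 to compound 3 (within the scatter) is thus small. Compound 2 `Cc1cccc(OCC2=NCCO2)c1` gives 70% in this assay. Compound 2 and compound 1 are built from the same atoms joined differently; the difference between the two cores is not broken down here. The number of compound 2 lies within the scatter of that of compound 1, while the gap from compound 2 to compound 3 lies beyond it.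

Compound 4 `O=[N+]([O-])c1cccc(OCC2=NCCO2)c1` has not yet been measured. It differs from compound 2 by nitro in place of methyl on an aromatic carbon. For the measured compounds named here, this is the same kind of change as the one from compound 1 to compound 3, but not the same: in compound 3 the nitro sits ortho to a group of 7 heavy atoms, whereas in compound 4 it sits meta to a group of 7 heavy atoms. The change has been measured only once, on a single pair.

The expectation for compound 4 rests on the step of a number 5 percentage points lower from compound 1 to compound 3 (within the scatter) having stayed within the scatter. A step of like size is expected, a number 5 percentage points lower from compound 2 to compound 4 (within the scatter). Compound 4 is accordingly estimated at 65% in this assay, with a range from 50% to 78%, an estimate that leans on one pair only.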

Compound 4, a percentage reported as activity, at one dose (the size of the read-out at that dose, not a potency): 35%
Estimate against measurement, compound 4: 30 percentage points above, outside the stated range (below it).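

In this assay, nitro in place of methyl on the second core gave a number 35 percentage points lower from compound 2 to compound 4 (beyond the scatter), so the small step seen on the first core did not carry over to this one. Set side by side, the two pairs show that this single change has no one size in this series: the same change on two cores in this assay, a number 5 percentage points lower (within the scatter) from compound 1 to compound 3 and a number 35 percentage points lower (beyond the scatter) from compound 2 to compound 4, 30 percentage points apart, beyond the scatter of two such steps. For the compounds shown here, what the two pairs do not show is the reason for the gap, including whether it is tied to the nitro sitting meta to a group of 7 heavy atoms in compound 4, and with only two cores they cannot say how large the step would be on a third.

The compounds shown carry only methyl or nitro on the six-membered aromatic ring, so it remains open how an amine, a carboxylic acid, a chlorine atom or a longer chain in that place would read in this assay. Also open, from the compounds shown here alone, is whether the same change would give steps of these sizes at any other dose, since each compound has one number at one dose.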